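From methyl to phenyl on the shared core

The source may report more compounds than this note shows. Statements on the series, on what has been measured and on what is new or still open speak of the compounds shown alone.

The measured compounds:
compound 1 `COC(=O)c1nc(C)n(-c2cccc(Br)c2)n1`
compound 2 `COC(=O)c1nc(C)n(-c2ccc(Cl)cc2)n1`
compound 3 `COC(=O)c1nc(C)n(-c2ccc(F)cc2)n1`

In a functional assay on Jurkat cells (Homo sapiens) for inhibition, read by MTT assay, with a stated time of 72 h (on this read-out lower numbers stand for stronger inhibition of growth and higher numbers for weaker inhibition of growth), compound 1 reaches only a limit, > 100000 nM, and this is the limit of > 100000 nM in this assay, at which 1 of the 3 values shown sits, and not a number. In this assay compound 2 gives 65900 nM. In this assay compound 3 gives 8700 nM, the lowest of the two numbers given. Among the compounds with values here, the only step that can be read between measured compounds is a 7.6-fold lower number from compound 2 to compound 3 (0.88 log units; beyond the scatter), a change on the aromatic ring attached to a ring nitrogen of the shared core.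

Compound 4 `COC(=O)c1nc(-c2ccccc2)n(-c2ccc(F)cc2)n1` keeps the fluoro of compound 3 and differs from it only here: phenyl in place of methyl on an aromatic carbon. Within the data shown here, none of the measured steps touches this part of the core; the one step that is known concerns the halogen on the other ring, so there is no measured guide to how large a change to expect, in either direction. The estimate for compound 4 therefore stays close to compound 3 and is given with a wide range: compound 4 is expected at 7000 nM, between 1000 nM and 50000 nM. This estimate for compound 4 amounts to a step of a 1.2-fold lower number from compound 3 to compound 4 (0.09 log units; within the scatter), which is not expected to go beyond the scatter.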

Compound 4, concentration for 50% growth inhibition: 10000 nM
For compound 4 the middle estimate is 1.4-fold (0.15 log units) below the measured one; the range from low to high includes it.
By their numbers in this assay, from the lowest: compounds 3 and 4 (each within the scatter of the next); then compound 2. At a limit, above all of these: compound 1.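

In this assay, the change of methyl to phenyl on the aromatic carbon between two ring nitrogen atoms gives a 1.1-fold higher number from compound 3 to compound 4 (0.06 log units; within the scatter) and so stays within the scatter, with the fluoro on the other ring kept. Within the data shown here, this is the first step read at this position of the shared core, since the earlier step concerned only the halogen on the aromatic ring attached to a ring nitrogen. It shows that, alongside that fluoro, the position accepts phenyl, with its 6 heavy atoms and its own ring, in place of the single carbon of methyl without a shift in growth inhibition that can be told from the scatter, and nothing at hand bears on why the two compounds read alike.

The compounds shown leave open whether a group of another kind at this position, such as an amine or a longer alkyl chain, would also leave the number in place, since methyl and phenyl are both built of carbon only. They also leave open whether phenyl would read the same with the chloro of compound 2 on the other ring, or with a carboxylic acid where the methoxycarbonyl group stands.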